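This account rests on a few compounds, and the source may have more. Where it says the series, first, only, none or still open, it means among the compounds named here.

Compound 1 `COc1ccc(-c2cc(-c3cccc(S(C)(=O)=O)c3)cnc2N)cn1` and compound 2 `COc1ccc(-c2cc(-c3ccc(S(N)(=O)=O)cc3)cnc2N)cn1` share a core and differ in the substituted aryl ring. In a physicochemical assay for lipophilicity, at pH 7.4 (on this read-out higher numbers stand for higher lipophilicity and lower numbers for lower lipophilicity), compound 1 gives 2.3, while compound 2 gives 1.8, the lower of the two numbers by a gap beyond the scatter. Compound 3 `COc1ccc(-c2cc(-c3ccc(NS(C)(=O)=O)cc3)cnc2N)cn1` has not been measured. It differs from compound 2 by methanesulfonamido in place of sulfamoyl on an aromatic carbon. For the measured compounds named here, no measured pair shows this exact exchange. The step from compound 2 to compound 3 is expected to be a number 0.60 log units higher from compound 2 to compound 3 (beyond the scatter) upward in this assay. Compound 3 is therefore estimated at 2.4, between 2 and 2.8.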

Compound 3, distribution coefficient: 2.2
For compound 3 the middle estimate is 0.20 log units above the measured one, within the range that was stated.
By their numbers in this assay, from the lowest: compound 2; then compounds 3 and 1 (each within the scatter of the next).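

Methanesulfonamido in place of sulfamoyl on an aromatic carbon, para to a large group, gives a number 0.40 log units higher from compound 2 to compound 3 (beyond the scatter) in this assay, the first reading of this exchange at this position. The step appears although both groups carry the same counts of hydrogen-bond donors and acceptors and neither carries a net charge. Nothing available accounts for its size. On these data alone, whether the exchange gives a similar step elsewhere on this ring remains open. So does where a carboxylic acid, an amine or a longer chain at this position would fall in this assay.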